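Swapping Imidazole for Chloroquinolinylamine: Expected Cytotoxicity

The source may hold more compounds than are shown below. What is called first, only, known or untested is meant among the compounds shown, and "the series" means these compounds.

Measured compounds:
compound 1, `Clc1ccc(C(c2ccccc2)(c2ccc(CN3CCCC3)cc2)n2ccnc2)cc1`, 88.1 uM
compound 2, `COc1ccc2nccc(NC(c3ccc(Cl)cc3)c3ccc(CN4CCCC4)cc3)c2c1`, 8.5 uM

Both compounds were tested in an ADME assay on KB cells (Homo sapiens) for cytotoxicity, read by MTT assay; on this read-out lower numbers stand for higher toxicity in this test and higher numbers for lower toxicity in this test. Compound 1 gives 88.1 uM and holds the higher of the two numbers, meaning it is the less toxic of the pair in this assay. Compound 2, which carries a quinolinylamino group on a carbon bearing two aromatic rings, gives 8.5 uM; the gap between compound 1 and compound 2 is beyond the usual scatter of repeated measurements, so compound 2 is clearly the more toxic one.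

Compound 3, `Clc1ccc(C(Nc2ccnc3cc(Cl)ccc23)(c2ccccc2)c2ccc(CN3CCCC3)cc2)cc1`, has not been measured yet. It differs from compound 1 in one place: (7-chloroquinolin-4-yl)amino in place of 1H-imidazol-1-yl on a saturated chain carbon bound to three aromatic carbons. This moves compound 3 structurally toward compound 2, which bears a closely related quinolinylamino group.

Because compound 2 gives 8.5 uM, a downward step in this assay is expected for compound 3, with a 5.9-fold lower number from compound 1 to compound 3 (0.77 log units; beyond the scatter) likely beyond the scatter. The expected value for compound 3 is 15 uM, within a range from 4 uM to 50 uM.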

Compound 3, half-maximal toxic concentration: 207 uM
Estimate against measurement, compound 3: 14-fold (1.14 log units) below, outside the stated range (above it).
By their numbers in this assay, from the lowest: compound 2; then compound 1; then compound 3.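

In this assay, (7-chloroquinolin-4-yl)amino in place of 1H-imidazol-1-yl on a saturated chain carbon bound to three aromatic carbons gives a 2.3-fold higher number from compound 1 to compound 3 (0.37 log units; beyond the scatter) and so moves toward lower toxicity in this test. The step is modest but beyond the usual scatter, and it shows that this position tolerates a group with more heavy atoms, a second aromatic ring and a hydrogen-bond donor without the number falling. No measurement at hand explains why the number rose.

As far as these compounds go, it remains open which part of the entering group carries the step, since the chlorine, the two six-membered aromatic rings and the hydrogen-bond donor all arrive together in this single change. A plain amino group or a quinolin-4-ylamino group without the chlorine, on the same saturated chain carbon, would help to separate these parts.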